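A Ring Swap on the Amide Carbonyl of Compound 3

The source may report more compounds than this note shows. Statements on the series, on what has been measured and on what is new or still open speak of the compounds shown alone.

Compound 3 `CC(C)(C)c1ccc(NC(=O)N2CCCN(C(=O)c3ccc(C(F)(F)F)cc3)CC2)cc1` was tested in an in vitro ADME assay on microsomes from liver (Homo sapiens) for metabolic stability, read by LC-MS (on this read-out higher numbers stand for a longer-lived compound and lower numbers for a shorter-lived compound), where compound 3 gives 0.0667 h. Among the three numbers recorded, compound 3 stands level with compound 2 `CC(C)(C)c1ccc(NC(=O)N2CCCN(C(=O)C3CCCCC3)CC2)cc1`, which in this assay gives 0.0667 h; together these two hold the highest numbers. Compound 1 `CC(C)(C)c1ccc(NC(=O)N2CCCN(C(=O)CCC3CCCC3)CC2)cc1` gives 0.05 h in this assay, and the difference a 1.3-fold higher number from compound 1 to compound 3 (0.13 log units; within the scatter) lies within the scatter.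

Compound 4 `CC(C)(C)c1ccc(NC(=O)N2CCCN(C(=O)C3CCOCC3)CC2)cc1` has not yet been measured. It differs from compound 3 in one place: oxan-4-yl in place of 4-(trifluoromethyl)phenyl on a carbonyl carbon.

Among the measured compounds shown here, three measured steps bear on this change, since each of them exchanges the group on the same carbonyl carbon. They read a 1.3-fold higher number from compound 1 to compound 2 (0.13 log units; within the scatter), a 1.3-fold higher number from compound 1 to compound 3 (0.13 log units; within the scatter) and no change at the digits printed from compound 2 to compound 3 (within the scatter). None of these reaches beyond the scatter, so exchanging the group on the carbonyl carbon has so far left this assay without any change that repeat measurement could tell apart. The account therefore expects no step beyond the scatter in this assay for compound 4 either, in neither direction.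

For compound 4 the expected value in this assay is 0.06 h, within an estimated range from 0.03 h to 0.13 h. This estimate amounts to an expected 1.1-fold lower number from compound 3 to compound 4 (0.05 log units; within the scatter).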

Compound 4, half-life: 0.183 h
The estimate for compound 4 lay 3.1-fold (0.48 log units) below the measured number; the whole stated range lies below it.
By their numbers in this assay, from the lowest: compounds 1, 2 and 3 (each within the scatter of the next); then compound 4.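

In this assay, among the compounds shown here, the carbonyl carbon no longer looks indifferent to its group, for oxan-4-yl gives the first steps at this place that lie beyond the scatter, whether it replaces 4-(trifluoromethyl)phenyl (a 2.7-fold higher number from compound 3 to compound 4 (0.44 log units; beyond the scatter)), cyclohexyl (a 2.7-fold higher number from compound 2 to compound 4 (0.44 log units; beyond the scatter)) or 2-cyclopentylethyl (a 3.7-fold higher number from compound 1 to compound 4 (0.56 log units; beyond the scatter)). Compound 4 thus stands alone at the top of the four, while the aromatic ring, the carbocyclic ring and the cyclopentyl-bearing chain of compounds 3, 2 and 1 remain within the scatter of one another, so that among these compounds only the group with a hetero atom in its ring separates from the rest, and it does so on a single example. Nothing shown here accounts for this separation.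

The compounds shown leave open whether the step belongs to the ring oxygen itself or to its place in the ring, which oxan-3-yl would address, and whether piperidin-4-yl, with a ring nitrogen, or an open ether chain such as 2-methoxyethyl would behave alike. They also leave open how far the step would carry over to any read-out other than this assay.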